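Swapping benzyl for isobutyl on a sulfonamide nitrogen

The compounds below may be only part of what the source reports. "The series", "measured", "known", "first", "only" and "open" are said of these compounds alone.

Of the compounds shown here, three have been measured in a physicochemical assay for lipophilicity, at pH 7.4; a higher number here means a more lipophilic compound, a lower number a more polar compound. Compound 1 `CCc1ccc(N(CC(C)C)S(=O)(=O)c2ccc3c(c2)C(O)CC(C2CCN(S(C)(=O)=O)CC2)O3)cc1` gives 3.22, compound 2 `CC(C)CN(c1ccc(C#N)cc1)S(=O)(=O)c1ccc2c(c1)C(O)CC(C1CCOCC1)O2` gives 3.07, and compound 3 `CCc1ccc(N(Cc2ccccc2)S(=O)(=O)c2ccc3c(c2)C(O)CC(C2CCOCC2)O3)cc1` gives 4.68. Compound 3 stands highest of the three, beyond the scatter above both others, with compound 1 closest to it and compound 2 furthest away. For the measured compounds named here, no pair of these measured compounds differs in only one place, so no single step can be read off directly. Compound 4 `CCc1ccc(N(CC(C)C)S(=O)(=O)c2ccc3c(c2)C(O)CC(C2CCOCC2)O3)cc1` has not yet been measured; its structure differs from compound 3 in one place: isopropyl in place of phenyl on a saturated chain carbon bound to a sulfonamide nitrogen. The step from compound 3 to compound 4 in this assay is expected to be downward and clearly beyond the scatter, by roughly a number 0.88 log units lower from compound 3 to compound 4 (beyond the scatter). Compound 4 is therefore estimated at 3.8, within a range from 3.2 to 4.4.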

Compound 4, distribution coefficient: 4.12
Compound 4: the middle estimate sits 0.32 log units below what was measured; the range from low to high includes it.
By their numbers in this assay, from the lowest: compounds 2 and 1 (each within the scatter of the next); then compound 4; then compound 3.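

Read by this assay, isopropyl in place of phenyl on a saturated chain carbon bound to a sulfonamide nitrogen gives a number 0.56 log units lower from compound 3 to compound 4 (beyond the scatter) as a modest step, so the number does respond to a change at this place. Compound 4 also ties in the other two compounds: ethyl in place of cyano on an aromatic carbon gives a number 1.05 log units higher from compound 2 to compound 4 (beyond the scatter) as a large step, and oxan-4-yl in place of 1-(methylsulfonyl)piperidin-4-yl on a saturated ring carbon gives a number 0.90 log units higher from compound 1 to compound 4 (beyond the scatter) as a modest one. Nothing available explains these steps. As far as these compounds go, with only phenyl and isopropyl seen at this place, how a longer chain or an amine there would read stays open.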